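Hydroxy in Place of Amino: Estimating Compound 4

The source may hold more compounds than are shown below. What is called first, only, known or untested is meant among the compounds shown, and "the series" means these compounds.

Compound 1 `COc1cc(-n2cnc3ccc(-c4cccc(N)c4)cc32)cc(OC)c1OC` gives 21 nM.
Compound 2 `COc1cccc(-c2ccc3ncn(-c4cc(OC)c(OC)c(OC)c4)c3c2)c1` gives 3310 nM.
Compound 3 `COc1ccc(-c2ccc3ncn(-c4cc(OC)c(OC)c(OC)c4)c3c2)cc1` gives 82 nM.

In a functional assay on SGC-7901 cells (Homo sapiens) for antiproliferative activity, read by MTT assay, with a stated time of 72 h (on this read-out higher numbers stand for weaker inhibition and lower numbers for stronger inhibition), compound 1 has the lowest number of the three; compound 3 is nearest, with a 3.9-fold higher number from compound 1 to compound 3 (0.59 log units; beyond the scatter), and compound 2 is furthest. Compound 4 `COc1cc(-n2cnc3ccc(-c4cccc(O)c4)cc32)cc(OC)c1OC` differs from compound 1 in one place: hydroxy in place of amino on an aromatic carbon. Among the measured compounds shown here, no measured pair swaps amino for hydroxy. The closest guide is the step in which methoxy replaces amino, a 160-fold higher number from compound 1 to compound 2 (2.20 log units; beyond the scatter), which was large. Hydroxy keeps one hydrogen-bond donor, as amino does, so a smaller weakening is expected. Compound 4 is therefore expected to give 150 nM, between 30 nM and 800 nM, an estimated step of a 7.1-fold higher number from compound 1 to compound 4 (0.85 log units; beyond the scatter).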

Compound 4, half-maximal inhibitory concentration: 53 nM
Beside the measured number, compound 4's estimate is 2.8-fold (0.45 log units) above it, within the range that was stated.
By their numbers in this assay, from the lowest: compound 1; then compounds 4 and 3 (each within the scatter of the next); then compound 2.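

In this assay, the oxygen at this place keeps most of the activity when it carries hydrogen, and the step for hydroxy in place of amino is only modest: a 2.5-fold higher number from compound 1 to compound 4 (0.40 log units; beyond the scatter). Adding a methyl to that oxygen is where the large loss lies, as removing it gives a 62-fold lower number from compound 2 to compound 4 (1.80 log units; beyond the scatter). The 3-hydroxyphenyl and 4-methoxyphenyl groups cannot be told apart here, with a 1.5-fold lower number from compound 3 to compound 4 (0.19 log units; within the scatter).

Nothing available explains why these changes have these effects. Going by these compounds, how a carboxylic acid or a dimethylamino group would behave in this same place remains open.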